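The compounds below may be only part of what the source reports. "The series", "measured", "known", "first", "only" and "open" are said of these compounds alone.

The study compares three measured compounds and one that awaits measurement, all of them brominated chalcone-derived structures. Compound 1 `O=C(/C=C/c1cc(Br)ccc1O)c1ccc(Br)cc1` and compound 2 `COc1cc(Br)cc(/C=C/C(=O)c2ccc(Br)cc2)c1O` share an open chalcone scaffold, while compound 3 `COc1cccc(C(=O)CC2C(C#N)=C(N)Oc3c(OC)cc(Br)cc32)c1` and compound 4 `COc1cccc(C(=O)CC2C(C#N)=C(N)Oc3ccc(Br)cc32)c1` carry a fused bicyclic core; how the core of compound 3 differs from that of compound 2 is not broken down here.

In a functional assay on MCF7 cells (Homo sapiens) for antiproliferative activity, read by sulforhodamine B assay, with a stated time of 72 h, tested at 10 uM (on this read-out higher numbers stand for a weaker effect at the one concentration tested and lower numbers for a stronger effect), compound 1 gives 28.7%. Compound 2 gives 64.6% in this assay, and compound 3 gives 55.9% in this assay. Between compound 2 and compound 1 the only change is hydrogen in place of methoxy on an aromatic carbon, and it produces a number 35.9 percentage points lower from compound 2 to compound 1 (beyond the scatter). Compound 3 and compound 2 lie within the scatter of one another, so nothing is said about their order.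

The change from compound 3 to compound 4 is hydrogen in place of methoxy on an aromatic carbon. Among the measured compounds shown here, it is the same kind of change as the one between compound 2 and compound 1, but the surroundings differ: in compound 2 the methoxy sits ortho to a hydroxy group, meta to a bromo group and meta to a large group, whereas in compound 3 it sits ortho to a fused ring, meta to a bromo group and meta to a fused ring.

The step from compound 3 to compound 4 is expected to be a number 15.9 percentage points lower from compound 3 to compound 4 (beyond the scatter), a lowering that rests on the large drop seen as a number 35.9 percentage points lower from compound 2 to compound 1 (beyond the scatter), tempered because the core of compound 3 gives 55.9% and the altered surroundings may not carry the full effect over. Compound 4 is therefore estimated at 40%, with a likely range from 20% to 62%.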

Compound 4, a percentage reported as activity, at one concentration (the size of the read-out at that concentration, not a potency): 51.2%
Estimate against measurement, compound 4: 11.2 percentage points below; low and high end bracket the measured number.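

In this assay, hydrogen in place of methoxy on an aromatic carbon gives a number 4.7 percentage points lower from compound 3 to compound 4 (within the scatter), so on this core the exchange has no effect that can be told apart from the scatter. The exchange therefore does not carry over in size from the core of compound 2 to the core of compound 3, and a step read on one core cannot simply be transferred to the other: the same change on two cores in this assay, a number 35.9 percentage points lower (beyond the scatter) from compound 2 to compound 1 and a number 4.7 percentage points lower (within the scatter) from compound 3 to compound 4, 31.2 percentage points apart, beyond the scatter of two such steps This comparison rests on a single pair for each core, so it does not show which feature of the cores or of the surroundings of the methoxy group sets the two steps apart, nor whether other changes would diverge in the same way.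

The compounds shown carry only methoxy or hydrogen at this aromatic carbon, which leaves open how an ethoxy group, a chloro group or an amine would read there on either core. On these data alone, it also remains open how the fused compounds would read with a chloro group in place of the bromo group, or with a carboxylic acid in place of the nitrile.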